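The source may report more compounds than this note shows. Statements on the series, on what has been measured and on what is new or still open speak of the compounds shown alone.

Of the compounds shown here, three sharing one core have been measured in a functional assay on DU-145 cells (Homo sapiens) for cytotoxicity, read by sulforhodamine B assay, with a stated time of 48 h; a lower number here means a stronger inhibitor, a higher number a weaker inhibitor. Compound 1 (`C[C@H]1CC[C@@H]2[C@@H](OC(=O)[C@]23CC(c2c(Cl)cccc2Cl)=NO3)[C@]2(C)C(=O)C=C[C@@]12O`) gives 38000 nM, compound 2 (`C[C@H]1CC[C@@H]2[C@@H](OC(=O)[C@]23CC(c2ccc(O)cc2)=NO3)[C@]2(C)C(=O)C=C[C@@]12O`) gives 93000 nM and compound 3 (`C[C@H]1CC[C@@H]2[C@@H](OC(=O)[C@]23CC(c2cccc([N+](=O)[O-])c2)=NO3)[C@]2(C)C(=O)C=C[C@@]12O`) gives 51000 nM. Compound 3 cannot be separated from either of the others, since a 1.3-fold higher number from compound 1 to compound 3 (0.13 log units; within the scatter) and a 1.8-fold lower number from compound 2 to compound 3 (0.26 log units; within the scatter) both lie within the scatter. Only a 2.4-fold higher number from compound 1 to compound 2 (0.39 log units; beyond the scatter) goes beyond the scatter, and that step is modest.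

Compound 4 (`C[C@H]1CC[C@@H]2[C@@H](OC(=O)[C@]23CC(c2ccccc2Cl)=NO3)[C@]2(C)C(=O)C=C[C@@]12O`) keeps the shared core and carries 2-chlorophenyl in place of 3-nitrophenyl on a carbon with a double bond to nitrogen. Going by the values given here, no measured step makes this exact exchange, so the three steps above are the only guide, and all of them are small. Among the compounds with values here, the closest measured group is the 2,6-dichlorophenyl of compound 1, which gives 38000 nM, the only measured compound with chlorine on its phenyl group. On that basis, no change beyond the scatter is expected in this assay. The expected step is a 1.1-fold lower number from compound 3 to compound 4 (0.05 log units; within the scatter), and this estimate stays within the scatter. For compound 4 the estimated value is 45000 nM, with an expected range of 24000 nM to 85000 nM.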

Compound 4, half-maximal inhibitory concentration: 19000 nM
For compound 4 the middle estimate is 2.4-fold (0.37 log units) above the measured one; the measured number lies below the stated range.
By their numbers in this assay, from the lowest: compounds 4, 1, 3 and 2 (each within the scatter of the next, the first and the last beyond it).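

In this assay, the 2-chlorophenyl group at this position gives the first clear separation from the 3-nitrophenyl group, with a 2.7-fold lower number from compound 3 to compound 4 (0.43 log units; beyond the scatter), and it also stands apart from the 4-hydroxyphenyl group, with a 4.9-fold lower number from compound 2 to compound 4 (0.69 log units; beyond the scatter). Chlorine-bearing groups can therefore be told apart from both of these groups only in part: a 2.0-fold lower number from compound 1 to compound 4 (0.30 log units; within the scatter) places the single-chlorine and two-chlorine compounds within the scatter of each other, yet compound 1 could not be separated from compound 3, so compound 3 goes against any simple division of the series by chlorine. The data shown offer no measurement that accounts for the step from 3-nitrophenyl to 2-chlorophenyl.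

The compounds shown leave open whether the place of the chlorine on the phenyl group matters, as 3-chlorophenyl or 4-chlorophenyl would show, and whether chlorine itself is needed, as 2-fluorophenyl, 2-bromophenyl or 2-methylphenyl would show. They also leave open how any of these groups compares with a plain phenyl group or with an aminophenyl group at this position.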